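From pentan-3-yl to 1-(methoxymethyl)ethyl

This account rests on a few compounds, and the source may have more. Where it says the series, first, only, none or still open, it means among the compounds named here.

Compound 1 `CC(C)Oc1cc(Oc2ccc(S(C)(=O)=O)cc2)cc(-c2cccc(=O)[nH]2)c1` gives 11000 nM
Compound 2 `CCC(CC)Oc1cc(Oc2cnc(C(=O)N(C)C)nc2)cc(-c2nccc(=O)[nH]2)c1` gives 469000 nM

In a physicochemical assay for solubility, in phosphate buffer, measured as kinetic solubility, with a stated time of 24 h, at pH 6.5 (on this read-out higher numbers stand for higher solubility and lower numbers for lower solubility), compound 2 holds the higher of the two numbers, and the gap to compound 1 lies beyond the scatter. Compound 3 `COC[C@H](C)Oc1cc(Oc2cnc(C(=O)N(C)C)nc2)cc(-c2nccc(=O)[nH]2)c1` carries 1-(methoxymethyl)ethyl in place of pentan-3-yl on an oxygen on an aromatic ring and has not yet been measured. Among the compounds with values here, no measured pair shows this change, which leaves the expectation uncertain. A slight rise in this assay is expected, with no step beyond the scatter. The estimated move is a 1.1-fold higher number from compound 2 to compound 3 (0.04 log units; within the scatter) and lies within the scatter. For compound 3 the estimated value is 520000 nM with an expected range from 270000 nM to 950000 nM in this read-out.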

Compound 3, solubility: 342000 nM
For compound 3 the middle estimate is 1.5-fold (0.18 log units) above the measured one; low and high end bracket the measured number.
By their numbers in this assay, from the lowest: compound 1; then compounds 3 and 2 (each within the scatter of the next).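

In this assay, placing 1-(methoxymethyl)ethyl in place of pentan-3-yl on an oxygen on an aromatic ring gives a 1.4-fold lower number from compound 2 to compound 3 (0.14 log units; within the scatter) and stays within the scatter. Within the data shown here, this is the first reading of a change at this position alone, since compound 1 and compound 2 differ in more than one place. So the ether oxygen in the chain leaves the two compounds indistinguishable on this read-out, and no measurement here offers an explanation. As far as these compounds go, whether an amine or a carboxylic acid on this chain would keep the number in the same range stays open. So does the opposite stereoisomer of 1-(methoxymethyl)ethyl.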